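The compounds below may be only part of what the source reports. "The series", "measured", "known", "first", "only" and "open" are said of these compounds alone.

Measured so far: compound 1 `CC(C(=O)NCc1ccc(C(F)(F)F)nc1-c1ccc(Cl)cc1)c1ccc(NS(C)(=O)=O)c(F)c1`, 0.7 nM; compound 2 `CC(C(=O)NCc1ccc(C(F)(F)F)nc1-c1ccc2cc[nH]c2c1)c1ccc(NS(C)(=O)=O)c(F)c1`, 20.3 nM.

For the measured compounds named here, in an assay on CHO cells for antagonist activity at transient receptor potential cation channel subfamily V member 1 (Homo sapiens), read by FLIPR (on this read-out higher numbers stand for weaker inhibition and lower numbers for stronger inhibition), compound 2 stands at the higher of the two numbers, with compound 1 as its only neighbour at the far lower value. Compound 3 `CC(C(=O)NCc1ccc(C(F)(F)F)nc1Cc1ccccc1)c1ccc(NS(C)(=O)=O)c(F)c1` differs from compound 2 by benzyl in place of 1H-indol-6-yl on an aromatic carbon. Going by the values given here, the one measured step at this position, a 29-fold higher number from compound 1 to compound 2 (1.46 log units; beyond the scatter), shows that a change of the group on this aromatic carbon can move this assay strongly. Among the compounds with values here, no measured step covers benzyl itself. Compound 3 is therefore expected to give 30 nM, ranging from 6 nM to 150 nM, which means an expected step of a 1.5-fold higher number from compound 2 to compound 3 (0.17 log units; within the scatter).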

Compound 3, inhibition constant: 141 nM
Compound 3: middle estimate off by 4.7-fold (0.67 log units), on the low side, and the stated range covers the measured number.
By their numbers in this assay, from the lowest: compound 1; then compound 2; then compound 3.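

In this assay, benzyl gives the highest number yet at this aromatic carbon, with a 6.9-fold higher number from compound 2 to compound 3 (0.84 log units; beyond the scatter) and a 200-fold higher number from compound 1 to compound 3 (2.30 log units; beyond the scatter). The position therefore separates all three groups, in the order 4-chlorophenyl, 1H-indol-6-yl, benzyl, rather than only the first two. Nothing available explains these differences.

The compounds shown leave open where an amine or a longer chain such as phenethyl would fall in this order. They also leave open whether a chlorine on the benzyl ring would lower the number.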